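The compounds below may be only part of what the source reports. "The series", "measured", "known", "first", "only" and "open" are said of these compounds alone.

The three measured compounds share one core. Compound 1 `COc1ccc(Cl)cc1N(CC(=O)N1CCc2ccccc21)S(=O)(=O)c1ccccc1` was tested in a functional assay on SH-SY5Y cells (Homo sapiens), read by MTT assay, with a stated time of 24 h; on this read-out lower numbers stand for an effect already at smaller amounts and higher numbers for an effect only at larger amounts of compound. In this assay compound 1 gives > 20000 nM, which is a limit of the assay rather than a number. In this assay compound 2 `CCCNC(=O)CN(c1cc(Cl)ccc1OC)S(=O)(=O)c1ccccc1` gives > 20000 nM, again a limit. In this assay compound 3 `COc1ccc(Cl)cc1N(CC(=O)Nc1ccccc1)S(=O)(=O)c1ccccc1` gives > 20000 nM, also a limit. Because of the limit of > 20000 nM in this assay, at which 3 of the 3 values shown sit, no step among these compounds can be read: a step that the two limits leave unreadable from compound 1 to compound 2, a step that the two limits leave unreadable from compound 1 to compound 3 and a step that the two limits leave unreadable from compound 2 to compound 3 are all left unreadable by the two limits. Compound 3 therefore stands only at a limit, and the two other values stand at the same limit.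

Compound 4 `COc1ccc(Cl)cc1N(CC(=O)NC1CCCCC1)S(=O)(=O)c1ccccc1` has not yet been measured. It differs from compound 3 by cyclohexyl in place of phenyl on an amide-type nitrogen. Going by the values given here, none of the measured steps has a readable size, so no direction can be drawn from them for this change. Compound 4 is expected to stay at the limit, with an estimated value of 20000 nM between 8000 nM and 50000 nM. For compound 4 the expected step is a number no higher from compound 3 to compound 4 (the limit leaves the size open).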

Compound 4, half-maximal effective concentration: 17600 nM
The estimate for compound 4 lay 1.1-fold (0.06 log units) above the measured number, within the range that was stated.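

In this assay, going by these compounds alone, compound 4 alone among the four gives a number rather than a limit, so cyclohexyl on the amide-type nitrogen provides the first readable value at this position. Even so, the comparisons give only floors, not sizes: an at least 1.1-fold lower number from compound 3 to compound 4 (0.05 log units; that floor lies within the scatter), an at least 1.1-fold lower number from compound 2 to compound 4 (0.05 log units; that floor lies within the scatter) and an at least 1.1-fold lower number from compound 1 to compound 4 (0.05 log units; that floor lies within the scatter). With each floor inside the scatter, no gain for cyclohexyl over phenyl or propyl, or for cyclohexylamino over 2,3-dihydro-1H-indol-1-yl, can be claimed, and the steps among compound 1, compound 2 and compound 3 remain unreadable: the limit of > 20000 nM in this assay, at which 3 of the 4 values shown sit.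

From the compounds shown here alone, the true size of these steps stays open, since the three partners of compound 4 have no numbers. Also open, going by these compounds, is whether cyclopentyl, cycloheptyl or a piperidin-4-yl group on the amide-type nitrogen would give a readable value.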